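The source may report more compounds than this note shows. Statements on the series, on what has been measured and on what is new or still open speak of the compounds shown alone.

Measured so far in an ADME assay on HEL cells (Homo sapiens) for cytotoxicity; on this read-out higher numbers stand for lower toxicity in this test and lower numbers for higher toxicity in this test:

- compound 1 `CCOc1ccc(/C=N/NC(=O)COc2cccc3ccccc23)cc1O` gives 100 ug/mL
- compound 2 `O=C(COc1cccc2ccccc12)N/N=C/c1ccc(Cl)cc1` gives 100 ug/mL
- compound 3 `COc1cc(/C=N/NC(=O)COc2cccc3ccccc23)cc(OC)c1OC` gives >= 20 ug/mL, a limit of the assay rather than a number

Compound 2 stands level with compound 1 at the digits shown; the two values lie within the usual scatter of repeated measurements, so no order between them can be read from this read-out. For compound 3 the result in this assay is only a limit of >= 20 ug/mL in this assay, at which 1 of the 3 values shown sits, and is not compared as a number here. Among the measured compounds shown here, no pair of these three compounds differs in a single place, so no measured step is available.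

Compound 4 `O=C(COc1cccc2ccccc12)N/N=C/c1ccccc1O` has not yet been measured in this assay. Relative to compound 2 the change is 2-hydroxyphenyl in place of 4-chlorophenyl on a carbon with a double bond to nitrogen. For the measured compounds named here, nothing among the measured compounds bears on a change of this kind, and the two numerical values shown sit at the same level. The expectation for compound 4 in this assay is therefore no shift beyond the scatter, with a step from compound 2 of no change at the digits printed from compound 2 to compound 4 (within the scatter). The estimated value for compound 4 is 100 ug/mL, with a range from 50 ug/mL to 200 ug/mL.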

Compound 4, minimum cytotoxic concentration: 20 ug/mL
Estimate against measurement, compound 4: 5.0-fold (0.70 log units) above; measured number below the stated range.
By their numbers in this assay, from the lowest: compound 4; then compounds 1 and 2 (each within the scatter of the next).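

In this assay, among the compounds shown here, the group on a carbon with a double bond to nitrogen is the first place with a measured single-place step: 2-hydroxyphenyl in place of 4-chlorophenyl gives a 5.0-fold lower number from compound 2 to compound 4 (0.70 log units; beyond the scatter), in the direction of higher toxicity in this test. The earlier compounds shown here offered no such step, and the matching values of compound 1 and compound 2 could have suggested a flat read-out, but this step shows that the read-out can shift with a change at this place. No measured property among the data shown accounts for the shift.

As far as these compounds go, compound 3 remains a limit rather than a number and does not enter the order: the limit of >= 20 ug/mL in this assay, at which 1 of the 4 values shown sits. Still open is whether the step follows the hydroxyl gained or the chlorine lost, and how an amine or a carboxylic acid in place of that hydroxyl would read at this place.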